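Swapping one methoxyphenyl arm for a tolyl group

The source may hold more compounds than are shown below. What is called first, only, known or untested is meant among the compounds shown, and "the series" means these compounds.

Measured so far:
compound 2, `C=CCn1c(=O)/c(=C\c2ccccc2OC)[nH]c(=O)/c1=C\c1ccccc1OC`: 6900 nM
compound 1, `C=CCn1c(=O)/c(=C\c2ccc(Cl)c(Cl)c2)[nH]c(=O)/c1=C\c1ccccc1OC`: "not active" (no number reported)

Among the measured compounds shown here, in a functional assay on HeLa cells (Homo sapiens) for cytotoxicity, read by CCK-8 assay, with a stated time of 72 h (a lower number here means a stronger inhibitor, a higher number a weaker inhibitor), compound 2 gives 6900 nM, the only number reported in this set. Compound 1 is recorded in this assay as "not active" (no number reported), with no figure attached. Compound 3, `C=CCn1c(=O)/c(=C\c2ccc(C)cc2)[nH]c(=O)/c1=C\c1ccccc1OC`, has not been tested. It differs from compound 2 by 4-methylphenyl in place of 2-methoxyphenyl on a double-bonded chain carbon bound to an aromatic carbon. For the measured compounds named here, no measured step of this kind is available; compound 1 shows that changing one aryl arm can remove measurable activity. A weakening step a 2.2-fold higher number from compound 2 to compound 3 (0.34 log units; beyond the scatter) is therefore expected. Compound 3 is estimated at 15000 nM, within 4000 nM to 60000 nM.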

Compound 3, half-maximal inhibitory concentration: "not active" (no number reported)
For compound 3 the study gives words and no number, and the estimate cannot be compared.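

In this assay, among the compounds shown here, compound 3 is reported in words and without a number, so no step from compound 2 to compound 3 can be read. The compounds shown leave open how large a change the replacement of this aryl arm brings. Nothing shown offers an explanation for this result.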